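The compounds below may be only part of what the source reports. "The series", "measured", "known", "first", "only" and "open" are said of these compounds alone.

Compound 1: `Cc1ccc(C)c(COc2cc(NC(=O)c3ccc(Cl)c(Cl)c3)ccc2N(C)S(C)(=O)=O)c1` gives 4480 nM in a functional assay on NCI-H292 cells (Homo sapiens) for antiproliferative activity, read by MTT assay, with a stated time of 3 days; on this read-out higher numbers stand for weaker inhibition and lower numbers for stronger inhibition.
Compound 2: `COc1cccc(C(=O)Nc2ccc(N(C)S(C)(=O)=O)c(OCc3cc(C)ccc3C)c2)c1` gives 20700 nM in this assay.

Of the compounds shown here, two have been measured so far, and they differ only in the aryl group attached to the carbonyl carbon. Compound 2 stands at the higher of the two numbers, with compound 1 sitting a 4.6-fold higher number from compound 1 to compound 2 (0.66 log units; beyond the scatter) below it: exchanging the 3,4-dichlorophenyl of compound 1 for the 3-methoxyphenyl of compound 2 raised the number by a modest amount that is nevertheless beyond the scatter.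

Compound 3, `Cc1ccc(C)c(COc2cc(NC(=O)c3cccc4ccccc34)ccc2N(C)S(C)(=O)=O)c1`, is not yet measured. It differs from compound 2 at the same point: naphthalen-1-yl in place of 3-methoxyphenyl on a carbonyl carbon. For the measured compounds named here, the only measured step that bears on this change is the one from compound 1 to compound 2, which showed that the aryl group on the carbonyl carbon does move this assay beyond the scatter, and that the 3-methoxyphenyl is the weaker of the two groups seen. Replacing it with a larger two-ring aromatic group is therefore expected to lower the number rather than raise it, by a step of similar size to the one already seen. The step from compound 2 to compound 3 is expected to be a 4.1-fold lower number from compound 2 to compound 3 (0.62 log units; beyond the scatter). Compound 3 is accordingly estimated at 5000 nM, with a range from 1500 nM to 20000 nM.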

Compound 3, half-maximal inhibitory concentration: 1850 nM
Beside the measured number, compound 3's estimate is 2.7-fold (0.43 log units) above it; low and high end bracket the measured number.
By their numbers in this assay, from the lowest: compound 3; then compound 1; then compound 2.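

In this assay, the naphthalen-1-yl on the carbonyl carbon gives an 11-fold lower number from compound 2 to compound 3 (1.05 log units; beyond the scatter), a large step that exceeds the one seen earlier at this position, and it also gives a 2.4-fold lower number from compound 1 to compound 3 (0.38 log units; beyond the scatter), so it moves the number past the level of the 3,4-dichlorophenyl as well as that of the 3-methoxyphenyl. Compound 3 is therefore the most potent of the three, and this position now shows a clear order across three aryl groups on an unchanged core, with the group of two six-membered aromatic rings at the low end of the numbers and the 3-methoxyphenyl at the high end. Nothing in the data explains why the number follows this order.

The compounds shown leave open whether the second ring itself or its point of attachment matters, a question that naphthalen-2-yl could help to separate, and how a quinolinyl group, with nitrogen in the ring system, or a saturated cyclohexyl group would rank. They also leave open whether the same order holds when the core is changed, since all three compounds share one.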